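A few compounds are considered here, and "the series" means these few. Any claim that something is new, unique, unknown or untested is made for them only; others in the source may bear on it.

Compound 1 `O=C1c2c[n+]([O-])c3ccccc3c2C(=O)c2c1c1ccccc1n2CCCCN1CCCCC1` gives 190 nM; compound 2 `CC1(C)OC[C@@H](Cn2cc(Cn3c4c(c5ccccc53)C(=O)c3c[n+]([O-])c5ccccc5c3C4=O)nn2)O1` gives 450 nM; compound 3 `CN1CCN(CCCn2c3c(c4ccccc42)C(=O)c2c[n+]([O-])c4ccccc4c2C3=O)CC1` gives 470 nM, all in a functional assay on A-375 cells (Homo sapiens) for cytotoxicity, read by MTT assay, with a stated time of 72 h; a higher number here means a weaker inhibitor, a lower number a stronger inhibitor.

Compound 3 carries the highest number of the three in this assay, though compound 2 sits within the scatter of it; only compound 1 lies clearly lower, as a 2.5-fold higher number from compound 1 to compound 3 (0.39 log units; beyond the scatter) shows. Compound 4 `O=C1c2c[n+]([O-])c3ccccc3c2C(=O)c2c1c1ccccc1n2Cc1cn(C[C@H](O)CO)nn1` differs from compound 3 in one place: 1-(2,3-dihydroxypropyl)-1H-1,2,3-triazol-4-yl in place of 2-(4-methylpiperazin-1-yl)ethyl on a saturated chain carbon bound to an aromatic nitrogen. Among the measured compounds shown here, the single measured step, a 2.5-fold higher number from compound 1 to compound 3 (0.39 log units; beyond the scatter), exchanges one chain end for another and bears only loosely on this change. Compound 2, which also bears a 1H-1,2,3-triazol-4-yl group on the carbon bound to the aromatic nitrogen, gives 450 nM, within the scatter of compound 3. Staying near compound 3, compound 4 is expected to show a 1.3-fold higher number from compound 3 to compound 4 (0.11 log units; within the scatter), an estimate of 600 nM with a range of 250 nM to 1500 nM.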

Compound 4, half-maximal inhibitory concentration: 350 nM
Beside the measured number, compound 4's estimate is 1.7-fold (0.23 log units) above it; the measured number falls inside the stated range.
By their numbers in this assay, from the lowest: compounds 1, 4, 2 and 3 (each within the scatter of the next, the first and the last beyond it).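

In this assay, 1-(2,3-dihydroxypropyl)-1H-1,2,3-triazol-4-yl in place of 2-(4-methylpiperazin-1-yl)ethyl gives a 1.3-fold lower number from compound 3 to compound 4 (0.13 log units; within the scatter), so this position accepts a neutrally counted triazole diol as readily as the piperazine chain. Freeing the diol from its 2,2-dimethyl-1,3-dioxolan-4-yl form gives a 1.3-fold lower number from compound 2 to compound 4 (0.11 log units; within the scatter), which also leaves the number within the scatter. The piperidine chain, which stood clearly apart from compound 3, shows no such separation here, with a 1.8-fold higher number from compound 1 to compound 4 (0.27 log units; within the scatter). On these data alone, whether a carboxylic acid or a primary amine on the triazole would behave alike stays open. No evidence at hand accounts for these results.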